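This account rests on a few compounds, and the source may have more. Where it says the series, first, only, none or still open, it means among the compounds named here.

Of the compounds shown here, two have so far been measured in an assay on isolated protein for inhibition of Amine oxidase [flavin-containing] B (Bos taurus); a lower number here means a stronger inhibitor, a higher number a weaker inhibitor. Compound 1 `CCC(=O)N1N=C(c2ccccc2)CC1c1ccc(Cl)cc1` gives 100000 nM, and compound 2 `CCC(=O)N1N=C(c2ccccc2)CC1c1ccc(F)cc1` gives 1150 nM. Going by the values given here, the single step between them, an 87-fold lower number from compound 1 to compound 2 (1.94 log units; beyond the scatter), exchanges the halogen on one aromatic ring. Among the compounds with values here, compound 2 thus stands at the lowest of the two numbers in this assay, with compound 1 as its only neighbour at a markedly higher value.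

Compound 3 `CCC(=O)N1N=C(c2ccc(OC)cc2)CC1c1ccc(F)cc1` differs from compound 2 by methoxy in place of hydrogen on an aromatic carbon, so that the phenyl of compound 2 becomes 4-methoxyphenyl. Within the data shown here, the measured step concerns the halogen on the other ring, not this position, so no measured step bears directly on the change; the data give no basis for a direction. The expected step is therefore a 1.2-fold lower number from compound 2 to compound 3 (0.06 log units; within the scatter), none beyond the scatter. Compound 3 is estimated at 1000 nM, with a range from 250 nM to 4000 nM.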

Compound 3, half-maximal inhibitory concentration: 100000 nM
For compound 3 the middle estimate is 100-fold (2.00 log units) below the measured one, outside the stated range (above it).
By their numbers in this assay, from the lowest: compound 2; then compounds 1 and 3 (each within the scatter of the next).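

In this assay, the phenyl of compound 2 proves to be a sensitive position, which the earlier pair could not show because it changed only the halogen on the other ring: going from phenyl to 4-methoxyphenyl gives an 87-fold higher number from compound 2 to compound 3 (1.94 log units; beyond the scatter) for methoxy in place of hydrogen on an aromatic carbon. A single substitution on either aromatic ring can therefore move the number well beyond the scatter, and compound 2 holds the lowest number of the three. Nothing at hand accounts for this step.

Open, as far as these compounds go, is whether the step is particular to methoxy or also holds for a hydroxy group, a methyl group or an amine on the same aromatic carbon. Also open, from the compounds shown here alone, is how a longer chain on the carbonyl would affect compound 2.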